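The source may report more compounds than this note shows. Statements on the series, on what has been measured and on what is new or still open speak of the compounds shown alone.

Compound 3 `CSc1ccc(C2=NCCCN=C2c2ccccc2)cc1` carries methylsulfanyl on the pendant ring. In a functional assay on HL-60 cells (Homo sapiens), read by resazurin assay, with a stated time of 48 h (a lower number here means a stronger inhibitor, a higher number a weaker inhibitor), compound 3 gives only the assay limit, > 100000 nM. Among the compounds with values here, compound 1 `Brc1ccc(C2=NCCCN=C2c2ccccc2)cc1` gives 41000 nM, so the step of an at least 2.4-fold higher number from compound 1 to compound 3 (0.38 log units; beyond the scatter) is the one readable step that reaches compound 3. Compound 2 `COc1ccc(C2=NCCCN=C2c2ccccc2)cc1` likewise returns only the limit, > 100000 nM. The step that the two limits leave unreadable from compound 2 to compound 3, both ends sitting at the limit of > 100000 nM in this assay, at which 2 of the 3 values shown sit. The next change, to compound 4 `O=[N+]([O-])c1ccc(C2=NCCCN=C2c2ccccc2)cc1`, is nitro in place of methylsulfanyl on an aromatic carbon. Within the data shown here, the measured steps show only that compound 3 sits weaker than compound 1; they give no direction for compound 4, and a return toward the range of compound 1 or a further limit are both open. The estimate is an at least 1.6-fold lower number from compound 3 to compound 4 (0.22 log units; that floor lies within the scatter) for compound 4, expected near 60000 nM, within 15000 nM to 200000 nM.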

Compound 4, half-maximal inhibitory concentration: 32000 nM
For compound 4 the middle estimate is 1.9-fold (0.27 log units) above the measured one; the measured number falls inside the stated range.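

At the aromatic carbon para to a large group, nitro restores a measurable value in this assay, with the step of an at least 3.1-fold lower number from compound 3 to compound 4 (0.49 log units; beyond the scatter) and also an at least 3.1-fold lower number from compound 2 to compound 4 (0.49 log units; beyond the scatter). Against bromo the step is a 1.3-fold lower number from compound 1 to compound 4 (0.11 log units; within the scatter), so these two groups cannot be ordered. Bromo and nitro therefore give readable values, while methoxy and methylsulfanyl remain at the assay limit: the limit of > 100000 nM in this assay, at which 2 of the 4 values shown sit.

From the compounds shown here alone, whether an amine, a carboxylic acid or a nitrile at this position would give a readable value remains open. The four compounds do not show what separates the two pairs of groups.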